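Shifting the Chlorine on the Chlorobenzyl Group

A few compounds are considered here, and "the series" means these few. Any claim that something is new, unique, unknown or untested is made for them only; others in the source may bear on it.

Compound 1, `Clc1ccc(Cn2cc(COc3ccccc3)nn2)cc1`, gives 26.1 ug/mL in a physicochemical assay, read by spectrophotometry, with a stated time of 30 min; a lower number here means a stronger inhibitor, a higher number a weaker inhibitor.
Compound 2, `Clc1cccc(Cn2cc(COc3ccccc3)nn2)c1`, gives 27.3 ug/mL in this assay.
Compound 3, `Clc1ccc(Cn2cc(COc3c(Cl)cc(Cl)cc3Cl)nn2)cc1`, gives 27.2 ug/mL in this assay.

Compound 1 and compound 2 differ only in one place: 3-chlorophenyl in place of 4-chlorophenyl on a saturated chain carbon bound to an aromatic nitrogen. This change produced a 1.0-fold higher number from compound 1 to compound 2 (0.02 log units; within the scatter), so the two compounds are indistinguishable within the scatter of the measurement. Compound 3 carries a different core from compound 1; how the two cores differ is not broken down here. The values of compound 3 and compound 1 lie within the scatter of each other, as do those of compound 3 and compound 2.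

Compound 4, `Clc1cccc(Cn2cc(COc3c(Cl)cc(Cl)cc3Cl)nn2)c1`, has not yet been measured. It differs from compound 3 in exactly one place: 3-chlorophenyl in place of 4-chlorophenyl on a saturated chain carbon bound to an aromatic nitrogen. This is the same change that separates compound 1 from compound 2, made at the same place and described in the same words, but now on the core of compound 3. Since the earlier step from compound 1 to compound 2 was a 1.0-fold higher number from compound 1 to compound 2 (0.02 log units; within the scatter), the step from compound 3 to compound 4 is expected to be of a similar size, a 1.0-fold higher number from compound 3 to compound 4 (0.00 log units; within the scatter), resting on that one earlier example only. Compound 4 is therefore estimated at 27.5 ug/mL in this assay, with a likely range from 18 ug/mL to 42 ug/mL.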

Compound 4, half-maximal inhibitory concentration: 16.4 ug/mL
The estimate for compound 4 lay 1.7-fold (0.22 log units) above the measured number; measured number outside the range, below it.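

In this assay, moving from 4-chlorobenzyl to 3-chlorobenzyl on the core of compound 3 gives a step that stays within the usual scatter of repeated measurements (a 1.7-fold lower number from compound 3 to compound 4 (0.22 log units; within the scatter)), and so does the same change on the core of compound 1 (a 1.0-fold higher number from compound 1 to compound 2 (0.02 log units; within the scatter)). On both cores shown, then, this change makes no difference that the measurement can resolve, so the two results agree in that limited sense, although each core offers only a single pair of compounds and neither pair shows a real difference that could be carried over. This does not show that the position of the chlorine is unimportant in general or that the change would behave the same way on a third core, and nothing measured here bears on why the numbers fall as they do.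

Every compound shown keeps a chlorine on the benzyl group, so it remains open what a methoxy group, an amine or a carboxylic acid would do in its place. On these data alone, it also remains open how a benzyl group with no chlorine at all, or a longer chain in place of the benzyl group's single saturated carbon, would read in this assay.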